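The source may report more compounds than this note shows. Statements on the series, on what has been measured and on what is new or still open speak of the compounds shown alone.

Among the compounds with values here, in an ADME assay on HepG2 cells (Homo sapiens) for cytotoxicity, read by MTT assay, with a stated time of 72 h (a higher number here means a weaker inhibitor, a lower number a stronger inhibitor), compound 2 `CC(C)=Cc1nc(Nc2ccccc2)c2cc([N+](=O)[O-])ccc2n1` gives 50000 nM, the only reading of the three that is a number. Compound 1 `Cc1ccc(S(=O)(=O)Cc2nc(Nc3cccc(Br)c3)c3ccccc3n2)cc1` reads > 15000 nM, which is a limit of the assay. Compound 3 `CC(C)=Cc1nc(Nc2cccc(C(F)(F)F)c2)c2cc([N+](=O)[O-])ccc2n1` reads > 100000 nM, which is also a limit.

Compound 4 `CC(C)=Cc1nc(Nc2ccc(F)cc2)c2cc([N+](=O)[O-])ccc2n1` has not yet been measured. It departs from compound 2 by fluoro in place of hydrogen on an aromatic carbon, para to a large group.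

Within the data shown here, the only measured step that bears on this change is an at least 2.0-fold higher number from compound 2 to compound 3 (0.30 log units; that floor lies within the scatter), made by trifluoromethyl in place of hydrogen on an aromatic carbon. That step is bounded on one side only and involves a different group, so it gives no firm size for the new change. It supports only a slight lean toward a higher number. In this assay a shift no larger than the scatter is therefore expected, and the estimated change is a 1.2-fold higher number from compound 2 to compound 4 (0.08 log units; within the scatter). For compound 4 the expected value is 60000 nM, with an estimated range of 25000 nM to 100000 nM.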

Compound 4, half-maximal inhibitory concentration: 27000 nM
The estimate for compound 4 lay 2.2-fold (0.35 log units) above the measured number, and the stated range covers the measured number.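

In this assay, fluoro in place of hydrogen on an aromatic carbon, para to a large group, gives a 1.9-fold lower number from compound 2 to compound 4 (0.27 log units; within the scatter); this is the first step among the compounds shown with a number at both ends, and on this reading phenyl and 4-fluorophenyl cannot be told apart in this series. Compound 3 reads > 100000 nM, which is a limit of the assay, so the step to it from compound 2 cannot be read for size and offers no firm comparison with the fluoro change. Nothing shown accounts for the reading of compound 4 or says what the fluoro group does in these cells.

Still open, on these data alone, is whether a single chloro or methoxy group at the same place on the ring would also stay within the scatter of compound 2, and whether fluoro placed elsewhere on that ring would behave as it does here. The nitro group is common to compound 2, compound 3 and compound 4, so the outcome of an amine or a nitrile in its place remains an open question for this series.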